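This account rests on a few compounds, and the source may have more. Where it says the series, first, only, none or still open, it means among the compounds named here.

Measured in a functional assay on MDA-MB-231 cells (Homo sapiens) for inhibition, read by MTT assay, with a stated time of 72 h; a lower number here means a stronger inhibitor, a higher number a weaker inhibitor:
- compound 1 `CC(C)[C@H](NC(=O)c1cc(Cl)ccc1OCCNC(=O)OC(C)(C)C)C(=O)Nc1ccc(C(F)(F)F)cc1Cl`: > 10000 nM
- compound 2 `CC(C)[C@H](NC(=O)c1cc(Cl)ccc1OCCN)C(=O)Nc1ccc(C(F)(F)F)cc1Cl`: 5440 nM

Compound 1 gives > 10000 nM, which is a limit and not a number. Among the measured compounds shown here, this is the only such reading so far: the limit of > 10000 nM in this assay, at which 1 of the 2 values shown sits.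

Compound 3 `CC(C)[C@H](NC(=O)c1cc(Cl)ccc1OCCNC(=O)OC(C)(C)C)C(=O)Nc1ccc(F)c(F)c1` differs from compound 1 by 3,4-difluorophenyl in place of 2-chloro-4-(trifluoromethyl)phenyl on an amide-type nitrogen. It keeps the tert-butoxycarbonyl group of compound 1.

For the measured compounds named here, the one measured step, an at least 1.8-fold lower number from compound 1 to compound 2 (0.26 log units; that floor lies within the scatter), concerns the amine nitrogen, so no measured step covers this change. With nothing to set a direction, no step beyond the scatter is expected in this assay, and a second limit reading is likely. The expected change is a step that the limit leaves unreadable from compound 1 to compound 3. For compound 3 the estimated value is 12000 nM, with an expected range of 5000 nM to 30000 nM.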

Compound 3, half-maximal inhibitory concentration: 3720 nM
Beside the measured number, compound 3's estimate is 3.2-fold (0.51 log units) above it; measured number below the stated range.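

Exchanging 2-chloro-4-(trifluoromethyl)phenyl for 3,4-difluorophenyl on the amide-type nitrogen gives, in this assay, an at least 2.6-fold lower number from compound 1 to compound 3 (0.42 log units; beyond the scatter). Among the compounds shown here, the tert-butoxycarbonyl group stays in place, so this position affects the read-out even with that group present, whereas the floor of the only earlier step, an at least 1.8-fold lower number from compound 1 to compound 2 (0.26 log units; that floor lies within the scatter), lies within the scatter. The true size of the new step stays unread, because compound 1 stands at a limit and the step is only a floor: the limit of > 10000 nM in this assay, at which 1 of the 3 values shown sits.

Which part of the exchanged group carries the step remains open; a plain phenyl or a phenyl with trifluoromethyl alone on the same nitrogen would help to separate the contributions. Also open, on these data alone, is whether 3,4-difluorophenyl gives a similar step when paired with the free amine of compound 2.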